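Fluoro on the pendant phenyl: two pairs compared

This account rests on a few compounds, and the source may have more. Where it says the series, first, only, none or still open, it means among the compounds named here.

Compound 1 `O=C(Nc1ccc(Oc2ccnc3[nH]ccc23)cc1)c1cc2cccnc2n(-c2ccc(Br)cc2)c1=O` gives 280 nM in a functional assay on A549 cells (Homo sapiens) for antiproliferative activity, read by MTT assay, with a stated time of 72 h; on this read-out lower numbers stand for stronger inhibition and higher numbers for weaker inhibition. Compound 2 `O=C(Nc1ccc(Oc2ccnc3[nH]ccc23)cc1)c1cc2cccnc2n(-c2ccc(Br)cc2F)c1=O` differs from compound 1 by fluoro in place of hydrogen on an aromatic carbon; in this assay compound 2 gives 1570 nM, and the step is a 5.6-fold higher number from compound 1 to compound 2 (0.75 log units; beyond the scatter). Compound 3 `Cn1ccc2c(Oc3ccc(NC(=O)c4cc5cccnc5n(-c5ccccc5)c4=O)cc3F)ccnc21` carries a different core; the difference between the two cores is not broken down here. In this assay compound 3 gives 430 nM; its gap to compound 1 is within the scatter, its gap to compound 2 beyond it.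

Compound 4 `Cn1ccc2c(Oc3ccc(NC(=O)c4cc5cccnc5n(-c5ccc(F)cc5)c4=O)cc3F)ccnc21` differs from compound 3 by fluoro in place of hydrogen on an aromatic carbon. This is the same kind of change as that between compound 1 and compound 2, not the same change: there the fluoro entered ortho to a large group and meta to a bromo group, here it enters para to a large group. Only the direction of the earlier step is carried over. In this assay the step from compound 3 to compound 4 is expected to be a 1.6-fold higher number from compound 3 to compound 4 (0.21 log units; within the scatter), smaller than the earlier one, because a 5.6-fold higher number from compound 1 to compound 2 (0.75 log units; beyond the scatter) was made at a different place. Compound 4 is therefore estimated at 700 nM, between 280 nM and 2000 nM.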

Compound 4, half-maximal inhibitory concentration: 280 nM
Beside the measured number, compound 4's estimate is 2.5-fold (0.40 log units) above it; the measured number falls inside the stated range.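

In this assay, fluoro in place of hydrogen on the pendant phenyl does not carry over as one fixed step from one core to the other: the same change on two cores in this assay, a 5.6-fold higher number (0.75 log units; beyond the scatter) from compound 1 to compound 2 and a 1.5-fold lower number (0.19 log units; within the scatter) from compound 3 to compound 4, 8.6-fold (0.94 log units) apart, beyond the scatter of two such steps.

On the core of compound 3, the change from phenyl to 4-fluorophenyl gives a 1.5-fold lower number from compound 3 to compound 4 (0.19 log units; within the scatter), so this fluoro costs no activity that can be told from the scatter, whereas the earlier fluoro step cost clear activity. This does not show that the core alone decides the outcome, as the fluoro here stands para to a large group, the earlier fluoro stands elsewhere on the pendant ring, and the pendant ring of compound 1 also carries a bromo group, so core and place cannot be separated.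

Still open, on these data alone, is whether fluoro at one and the same place on the pendant ring would behave alike on both cores. Also open, as far as these compounds go, is how an amine or a methoxy group in place of the fluoro of compound 4 would read on this core.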